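This account rests on a few compounds, and the source may have more. Where it says the series, first, only, none or still open, it means among the compounds named here.

Of the compounds shown here, two built on one shared core have numbers so far. For the measured compounds named here, in a functional assay, read by spectrophotometry, with a stated time of 2 h (on this read-out higher numbers stand for weaker inhibition and lower numbers for stronger inhibition), compound 1 (`CC(C)[C@@H]1CC[C@@H](C)C[C@@]12N(C)C(=O)[C@@H]1[C@H]3C(=O)N(C)C(=O)[C@H]3ON12`) gives 1400 ug/mL and compound 2 (`CC(C)[C@@H]1CC[C@@H](C)C[C@@]12N(C)C(=O)[C@@H]1[C@H]3C(=O)N(c4ccc(Cl)cc4)C(=O)[C@H]3ON12`) gives 2000 ug/mL, so compound 1 stands within the scatter of its only measured neighbour. Compound 3 (`Cc1ccc(N2C(=O)[C@H]3[C@H](ON4[C@@H]3C(=O)N(C)[C@@]43C[C@H](C)CC[C@H]3C(C)C)C2=O)c(C)c1`) is still to be measured. Its change from the core of compound 1 is 2,4-dimethylphenyl in place of methyl on an amide-type nitrogen in a ring. Going by the values given here, one measured step bears on this, the exchange of that same methyl for 4-chlorophenyl, which gave a 1.4-fold higher number from compound 1 to compound 2 (0.15 log units; within the scatter). That single step stayed within the scatter, so no step beyond the scatter is expected in this assay. The expected step is a 1.3-fold higher number from compound 1 to compound 3 (0.11 log units; within the scatter). For compound 3 the estimated value is 1800 ug/mL, with an expected range from 900 ug/mL to 3600 ug/mL.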

Compound 3, half-maximal inhibitory concentration: 420 ug/mL
Beside the measured number, compound 3's estimate is 4.3-fold (0.63 log units) above it; the measured number lies below the stated range.
By their numbers in this assay, from the lowest: compound 3; then compounds 1 and 2 (each within the scatter of the next).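

In this assay, the amide-type nitrogen in the ring now proves able to shift the number beyond the scatter: 2,4-dimethylphenyl in place of methyl gives a 3.3-fold lower number from compound 1 to compound 3 (0.52 log units; beyond the scatter), whereas the exchange for 4-chlorophenyl did not leave the scatter. An aromatic ring entering at this nitrogen therefore does not set the number by itself, since 2,4-dimethylphenyl in place of 4-chlorophenyl gives a 4.8-fold lower number from compound 2 to compound 3 (0.68 log units; beyond the scatter), and the two groups differ only in what that ring carries. Nothing measured here explains this difference.

As far as these compounds go, it remains open whether both methyl groups on the ring are needed, as 2-methylphenyl or 4-methylphenyl would show. The compounds shown also leave open how this nitrogen responds to a benzyl group, a longer alkyl chain, or a phenyl ring carrying a carboxylic acid or an amine.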